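Adding an open-chain group to the nitrogen of compound 2

This account rests on a few compounds, and the source may have more. Where it says the series, first, only, none or still open, it means among the compounds named here.

Of the compounds shown here, two sharing a core have numbers so far. In a functional assay on MCF7 cells (Homo sapiens) for antiproliferative activity, read by MTT assay, with a stated time of 48 h (on this read-out higher numbers stand for weaker inhibition and lower numbers for stronger inhibition), compound 1 (`Nc1ccc(/N=N/c2ccc(-c3nc4ncccc4[nH]3)cc2)cc1`) gives 2840 nM and compound 2 (`Nc1ccc(-c2nc3ncccc3[nH]2)cc1`) gives 710 nM as the lower of the two numbers, with a gap between them that lies beyond the scatter. Compound 2 is therefore the stronger inhibitor of this pair and serves as the reference point.

Compound 3 (`CC(=O)C(=NNc1ccc(-c2nc3ncccc3[nH]2)cc1)C(C)=O`) has not yet been measured. The change is a group of 8 heavy atoms (5 carbon, 1 nitrogen, 2 oxygen; no ring) in place of a hydrogen atom, on a nitrogen on an aromatic ring on a nitrogen on an aromatic ring, so a group with no ring stands in place of a hydrogen atom.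

Going by the values given here, no measured step covers this change, so the expectation is loose. A modest step toward a higher number, meaning weaker inhibition, is expected in this assay and may lie near the edge of the scatter. Among the compounds with values here, the only other reading, compound 1 at 2840 nM in this series, also lies on the higher side of compound 2. The estimated 1.8-fold higher number from compound 2 to compound 3 (0.26 log units; within the scatter) is of that modest size and remains uncertain. For compound 3 the estimated value is 1300 nM with an expected range from 250 nM to 6000 nM in this read-out.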

Compound 3, half-maximal inhibitory concentration: 2110 nM
Compound 3: middle estimate off by 1.6-fold (0.21 log units), on the low side; measured number inside the range.
By their numbers in this assay, from the lowest: compound 2; then compounds 3 and 1 (each within the scatter of the next).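

In this assay, going by these compounds alone, the first reading at this position gives a 3.0-fold higher number from compound 2 to compound 3 (0.47 log units; beyond the scatter), so placing an open-chain group on the nitrogen on an aromatic ring in place of a hydrogen atom costs inhibition by a margin that the scatter does not cover. The cost is modest rather than a complete loss of effect: with this group carried on the shared core, compound 3 still gives 2110 nM, so this nitrogen does not have to keep its hydrogen atom for a number to be read in this cell assay. The measurements at hand say nothing about what lies behind this step.

With a single group at this nitrogen, the shift cannot yet be assigned to the group as a whole or to any one part of it, such as its carbonyl groups. The compounds shown also leave open whether a small methyl group, a longer alkyl chain or a chain ending in a carboxylic acid on the same nitrogen would stay close to compound 2 or move as far as compound 3.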